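This account rests on a few compounds, and the source may have more. Where it says the series, first, only, none or still open, it means among the compounds named here.

Compound 1 `Cc1cc(C)c(-n2c(Cl)cn3c(CN(CCC(F)(F)F)CC4CC4)c(C(F)(F)F)nc23)c(C)c1` belongs to a small set built on a shared core and tested in an assay on cells for displacement of a labelled ligand from corticotropin-releasing factor receptor 1 (Homo sapiens), with a stated time of 100 min (on this read-out higher numbers stand for weaker inhibition and lower numbers for stronger inhibition), where compound 1 gives 16 nM. Going by the values given here, its only measured companion is compound 2 `C=CCN(CC=C)Cc1c(C(F)(F)F)nc2n(-c3c(C)cc(C)cc3C)c(Cl)cn12`, which gives 13 nM in this assay; the step runs a 1.2-fold lower number from compound 1 to compound 2 (0.09 log units; within the scatter), so the two numbers sit side by side and neither can be set above the other.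

Compound 3 `Cc1cc(C)c(-n2c(Cl)cn3c(CN(CCC(F)(F)F)Cc4ccc(Cl)cc4)c(C(F)(F)F)nc23)c(C)c1` has not yet been measured in this assay. It differs from compound 1 by 4-chlorophenyl in place of cyclopropyl on a saturated chain carbon bound to an amine nitrogen. Among the compounds with values here, no measured step covers this exact replacement. Within the data shown here, the one step on hand, a 1.2-fold lower number from compound 1 to compound 2 (0.09 log units; within the scatter), swaps out the whole amine substituent and stays within the scatter, which suggests that this branch of the molecule can be altered without a sharp change in this assay. On that basis one expects no step beyond the scatter, and the estimated step is a 1.1-fold lower number from compound 1 to compound 3 (0.03 log units; within the scatter). For compound 3 the estimated value in this assay is 15 nM, with an expected range from 5 nM to 50 nM.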

Compound 3, inhibition constant: 12 nM
The estimate for compound 3 lay 1.3-fold (0.10 log units) above the measured number; measured number inside the range.
By their numbers in this assay, from the lowest: compounds 3, 2 and 1 (each within the scatter of the next).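

In this assay, putting 4-chlorophenyl in place of cyclopropyl on a saturated chain carbon bound to an amine nitrogen gives a 1.3-fold lower number from compound 1 to compound 3 (0.12 log units; within the scatter) and so leaves the number level, although a three-membered non-aromatic ring of carbon only, with 3 heavy atoms, gives way to a six-membered aromatic ring with 7 heavy atoms, chlorine among them. The earlier step had exchanged the whole amine substituent, whereas this one keeps the 3,3,3-trifluoropropyl group in place and alters a single group, which ties the flat response to this one position and shows that it extends to an aromatic ring bearing chlorine. Nothing on hand accounts for why the number holds across so large a change in the group.

The compounds shown leave open whether a plain benzyl group without the chlorine, a benzyl group carrying a carboxylic acid or an amine, or a longer chain ending in the same ring would read the same way. Also open, from the compounds shown here alone, is whether the 3,3,3-trifluoropropyl group can itself be exchanged, for instance for a hydroxyethyl group, with the 4-chlorobenzyl group held in place.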